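Trifluoromethyl to Methoxy on a Pair at the Limit

The compounds below may be only part of what the source reports. "The series", "measured", "known", "first", "only" and "open" are said of these compounds alone.

Two compounds share one core and differ only in the group on the outer aromatic ring. Compound 1 `O=C1CC(c2nc(-c3ccccn3)no2)CN1c1ccc(F)cc1` was tested in an in vitro functional assay on HEK293-A cells for positive allosteric modulation of metabotropic glutamate receptor 5 (Homo sapiens), read by FLIPR and calcium flux (on this read-out lower numbers stand for an effect already at smaller amounts and higher numbers for an effect only at larger amounts of compound), and gave only the limit of the assay, > 10000 nM. Compound 2 `O=C1CC(c2nc(-c3cccc(C(F)(F)F)c3)no2)CN1c1ccc(F)cc1` likewise gave only a limit in this assay, > 10000 nM. Going by the values given here, both values sit at the same place, (the limit of > 10000 nM in this assay, at which 2 of the 2 values shown sit), so neither compound shows an effect within the range tested, and no step between them can be sized. The next compound, compound 3 `COc1cccc(-c2noc(C3CC(=O)N(c4ccc(F)cc4)C3)n2)c1`, differs from compound 2 in a single place: methoxy in place of trifluoromethyl on an aromatic carbon, a methoxy in place of trifluoromethyl on an aromatic carbon. Among the compounds with values here, no measured step tells how such a change moves this assay; with both measured compounds at the limit, no movement beyond the scatter can be foreseen. Compound 3 is therefore expected to give about 10000 nM, between 3000 nM and 30000 nM. The step of a number no higher from compound 2 to compound 3 (the limit leaves the size open) is expected to be none beyond the scatter.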

Compound 3, half-maximal effective concentration: 1100 nM
For compound 3 the middle estimate is 9.1-fold (0.96 log units) above the measured one; measured number outside the range, below it.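

At this position the group on the aromatic carbon decides whether any response appears in this assay: methoxy in place of trifluoromethyl gives an at least 9.0-fold lower number from compound 2 to compound 3 (0.95 log units; beyond the scatter). The change from pyridin-2-yl to 3-methoxyphenyl gives an at least 9.0-fold lower number from compound 1 to compound 3 (0.95 log units; beyond the scatter), so the shared core can give a measurable value when this ring carries methoxy. Compound 3 is the only one of the three to leave the limit, and both steps are bounds rather than sizes: the limit of > 10000 nM in this assay, at which 2 of the 3 values shown sit.

Going by these compounds, the true size of either step remains unknown, and so does whether the gain is specific to methoxy. An ethoxy, a hydroxy or an amine on the same aromatic carbon, or a plain phenyl ring with no such group, would show whether the response depends on methoxy itself.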